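The source may hold more compounds than are shown below. What is called first, only, known or untested is meant among the compounds shown, and "the series" means these compounds.

Of the compounds shown here, two have been measured in an assay on isolated protein for inhibition of Rho-associated protein kinase 2 (Homo sapiens); a lower number here means a stronger inhibitor, a higher number a weaker inhibitor. Compound 1 `Cc1ccc2c(c1)CC(C(=O)Nc1ccc(-c3cn[nH]c3)cc1)CO2` gives 10 nM in this assay, and compound 2 `COc1cc(-c2cn[nH]c2)ccc1NC(=O)C1COc2ccc(Cl)cc2C1` gives 3 nM. Compound 2 therefore stands with the lower of the two values, and its distance from compound 1 lies beyond the usual scatter of repeated measurements. Compound 3 `COc1cc(-c2cn[nH]c2)ccc1NC(=O)C1COc2ccc(C)cc2C1` has not yet been measured; it differs from compound 2 in a single place: methyl in place of chloro on an aromatic carbon. Among the compounds with values here, compound 1 also carries a methyl, but it differs from compound 2 in more than one place, so the two measured values do not isolate this exchange, and no step of this kind between measured compounds is available. For compound 3 the expected change is a 1.7-fold higher number from compound 2 to compound 3 (0.22 log units; within the scatter), a slightly higher number that may well fall within the scatter. Compound 3 is thus estimated at 5 nM, with a range from 2 nM to 15 nM.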

Compound 3, half-maximal inhibitory concentration: 4 nM
Estimate against measurement, compound 3: 1.3-fold (0.10 log units) above; measured number inside the range.
By their numbers in this assay, from the lowest: compounds 2 and 3 (each within the scatter of the next); then compound 1.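

In this assay the exchange of chloro for methyl on this aromatic carbon can now be read on its own, and a 1.3-fold higher number from compound 2 to compound 3 (0.12 log units; within the scatter) shows that the two groups cannot be told apart at this position. Within the data shown here, compound 3 also provides the first single-place comparison with compound 1: methoxy in place of hydrogen on an aromatic carbon gives a 2.5-fold lower number from compound 1 to compound 3 (0.40 log units; beyond the scatter) and is thus a modest step that can be distinguished from the scatter. No available evidence bears on the reason for the size of either step.

The compounds shown leave open whether other groups on this aromatic carbon, such as an amine or a carboxylic acid, would fit in the same way as chloro and methyl. Among these compounds, the methoxy step is seen only with methyl on the other ring, so whether it has the same size alongside chloro remains open.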